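The source may report more compounds than this note shows. Statements on the series, on what has been measured and on what is new or still open speak of the compounds shown alone.

Measured so far:
compound 1, `COc1ccc2[nH]c3c(c2c1)CCNC31CCN(Cc2ccc([N+](=O)[O-])cc2F)CC1`, 5900 nM;
compound 2, `COc1ccc2[nH]c3c(c2c1)CCNC31CCN(Cc2ccc(Br)c(F)c2)CC1`, 1800 nM;
compound 3, `COc1ccc2[nH]c3c(c2c1)CCNC31CCN(Cc2ccc(F)c(F)c2F)CC1`, 4100 nM.

All three share one core and differ only in the aryl group on the saturated chain carbon bound to the amine nitrogen in a ring. In an assay on FRT cells for positive allosteric modulation of Cystic fibrosis transmembrane conductance regulator variant N1303K (Homo sapiens), in the presence of a further agent that is not named here (a lower number here means that less compound is needed, a higher number that more compound is needed for the effect), compound 1 gives the highest of the three numbers. Its nearest neighbour is compound 3, reached by a 1.4-fold lower number from compound 1 to compound 3 (0.16 log units; within the scatter). Compound 2 lies furthest away, reached by a 3.3-fold lower number from compound 1 to compound 2 (0.52 log units; beyond the scatter), and the gap between compound 2 and compound 3 is a 2.3-fold higher number from compound 2 to compound 3 (0.36 log units; beyond the scatter).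

Compound 4, `COc1ccc2[nH]c3c(c2c1)CCNC31CCN(Cc2cccc(F)c2F)CC1`, has not yet been measured. It differs from compound 1 as follows: 2,3-difluorophenyl in place of 2-fluoro-4-nitrophenyl on a saturated chain carbon bound to an amine nitrogen in a ring. Within the data shown here, the step that bears most directly on this is the one from compound 1 to compound 3, where another fluorine-only aryl group entered and the number stayed within the scatter; the step from compound 1 to compound 2 shows that a larger drop is possible, but that aryl group carries a bromine that compound 4 lacks. The expectation for compound 4 is therefore a small step, if any, toward a lower number, a 1.3-fold lower number from compound 1 to compound 4 (0.12 log units; within the scatter). Compound 4 is estimated at 4500 nM, with a likely range from 2000 nM to 10000 nM.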

Compound 4, half-maximal effective concentration: 13600 nM
Beside the measured number, compound 4's estimate is 3.0-fold (0.48 log units) below it; measured number outside the range, above it.
By their numbers in this assay, from the lowest: compound 2; then compounds 3 and 1 (each within the scatter of the next); then compound 4.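

The result shows that fluorine-only aryl groups are not interchangeable at this position: in this assay, hydrogen in place of fluoro on an aromatic carbon gives a clear rise (a 3.3-fold higher number from compound 3 to compound 4 (0.52 log units; beyond the scatter)), so the 2,3-difluorophenyl and 2,3,4-trifluorophenyl groups part ways on a single ring substituent. The 2,3-difluorophenyl group also falls behind both other aryl groups (a 2.3-fold higher number from compound 1 to compound 4 (0.36 log units; beyond the scatter); a 7.6-fold higher number from compound 2 to compound 4 (0.88 log units; beyond the scatter)), and among these four compounds only its name lacks a 4-substituent, whereas 2-fluoro-4-nitrophenyl, 4-bromo-3-fluorophenyl and 2,3,4-trifluorophenyl all carry one, with no compound shown going against this pattern. Nothing shown here offers an explanation for these differences.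

From the compounds shown here alone, what remains open is whether any group in that place will serve, since a chlorine, a methyl or a methoxy group on the 2,3-difluorophenyl ring would test how far the pattern holds. It is also open how much of the lower number of compound 2 belongs to its bromine, as no pair shown changes the bromine alone.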